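The compounds below may be only part of what the source reports. "The series", "measured", "known", "first", "only" and "open" are said of these compounds alone.

In a functional assay on MDA-MB-231 cells (Homo sapiens) for antiproliferative activity, read by MTT assay, with a stated time of 48 h (a lower number here means a stronger inhibitor, a higher number a weaker inhibitor), compound 1 `CCS(=O)(=O)N1CCN(c2ncnc3sc(-c4ccc(N5CCN(C)CC5)cc4)cc23)CC1` gives 7330 nM, compound 2 `CN1CCN(c2ccc(-c3cc4c(N5CCN(S(=O)(=O)N6CCCCC6)CC5)ncnc4s3)cc2)CC1` gives 8130 nM, and compound 3 `CN1CCN(c2ccc(-c3cc4c(N5CCN(C(=O)Nc6ccccc6)CC5)ncnc4s3)cc2)CC1` gives 7590 nM. Compound 3 therefore stands within the scatter of both other compounds, and the three show no order among themselves. Compound 4 `CN1CCN(c2ccc(-c3cc4c(N5CCN(C(=O)Nc6ccc(Cl)cc6)CC5)ncnc4s3)cc2)CC1` differs from compound 3 by chloro in place of hydrogen on an aromatic carbon, which turns phenylcarbamoyl to (4-chlorophenyl)carbamoyl. Within the data shown here, no measured step tests this exact change. The nearest evidence comes from exchanges of the whole group on the amine nitrogen in a ring, and these gave a 1.1-fold higher number from compound 1 to compound 2 (0.04 log units; within the scatter), a 1.0-fold higher number from compound 1 to compound 3 (0.02 log units; within the scatter) and a 1.1-fold lower number from compound 2 to compound 3 (0.03 log units; within the scatter). All three stayed within the scatter, although each replaced far more than one atom. On that evidence, no step beyond the scatter is expected in this assay, and no direction can be argued with confidence. The expected result is a 1.2-fold lower number from compound 3 to compound 4 (0.07 log units; within the scatter). For compound 4 the estimate is 6500 nM, with an expected range of 3000 nM to 12000 nM.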

Compound 4, half-maximal inhibitory concentration: 5440 nM
Beside the measured number, compound 4's estimate is 1.2-fold (0.08 log units) above it; the range from low to high includes it.
By their numbers in this assay, from the lowest: compounds 4, 1, 3 and 2 (each within the scatter of the next).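

In this assay, among these compounds, chloro on an aromatic carbon of a six-membered aromatic ring of carbon only, para to a large group, gives the first single-atom reading at this position: a 1.4-fold lower number from compound 3 to compound 4 (0.14 log units; within the scatter). The exchanges of the whole group on the amine nitrogen in a ring read the same way, with a 1.5-fold lower number from compound 2 to compound 4 (0.17 log units; within the scatter) and a 1.3-fold lower number from compound 1 to compound 4 (0.13 log units; within the scatter), so neither this small change nor the larger ones leave the scatter. No measurement at hand offers an explanation for these readings.

As far as these compounds go, it remains open whether a methoxy group, an amine or a carboxylic acid at this position would give a step beyond the scatter. From the compounds shown here alone, it is equally open whether a change to the shared core, rather than to this group, would do so in this assay.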